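Methylsulfonyl in Place of Hydrogen on Compound 3

The source may hold more compounds than are shown below. What is called first, only, known or untested is meant among the compounds shown, and "the series" means these compounds.

Compound 1, `CS(=O)(=O)c1ccccc1Nc1nc2c(Nc3ccc(C(F)(F)F)cc3)ncnc2s1`: 234 nM
Compound 2, `N#Cc1cc(Cl)c(Nc2nc3c(Nc4ccc(C(F)(F)F)cc4)ncnc3s2)c(Cl)c1`: 95 nM
Compound 3, `Clc1cccc(Cl)c1Nc1nc2c(Nc3ccccc3)ncnc2s1`: 176 nM

Of the compounds shown here, three sharing one core have been measured in a functional assay on HEK293 cells for antagonist activity at transient receptor potential cation channel subfamily V member 1 (Homo sapiens), read by calcium flux; a higher number here means a weaker inhibitor, a lower number a stronger inhibitor. Compound 3 stands second highest of the three numbers; its nearest neighbour is compound 1, and the two lie within the scatter of each other, as do compound 3 and compound 2.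

Compound 4, `CS(=O)(=O)c1ccc(Nc2ncnc3sc(Nc4c(Cl)cccc4Cl)nc23)cc1`, has not been measured. It differs from compound 3 in one place: methylsulfonyl in place of hydrogen on an aromatic carbon, on the six-membered ring of carbon only, para to a large group.

For the measured compounds named here, the only measured step, a 2.5-fold lower number from compound 1 to compound 2 (0.39 log units; beyond the scatter), alters a different part of the molecule, the group carried on the nitrogen attached to the core, and so gives no direct guide to a change on this ring. Going by the values given here, no measured pair shows what adding a methylsulfonyl here does. The expectation therefore rests on the absence of evidence for a large effect: the number for compound 4 is estimated to lie close to that of compound 3, with a 1.1-fold lower number from compound 3 to compound 4 (0.04 log units; within the scatter) as the expected step, in either direction within a broad range. Compound 4 is estimated at 160 nM, between 50 nM and 500 nM.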

Compound 4, half-maximal inhibitory concentration: 5 nM
The estimate for compound 4 lay 32-fold (1.51 log units) above the measured number; the whole stated range lies above it.
By their numbers in this assay, from the lowest: compound 4; then compounds 2, 3 and 1 (each within the scatter of the next, the first and the last beyond it).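

In this assay, methylsulfonyl in place of hydrogen on an aromatic carbon, para to a large group, gives a 35-fold lower number from compound 3 to compound 4 (1.55 log units; beyond the scatter). For the compounds shown here, this shows that the group on this carbon can change the number strongly, and by much more than the one earlier step, on the other side of the molecule, a 2.5-fold lower number from compound 1 to compound 2 (0.39 log units; beyond the scatter). No measurement presented here accounts for the size of this gain.

On these data alone, how an amine, a carboxylic acid or a methoxy group on the same carbon would compare with methylsulfonyl remains open, so the gain cannot yet be tied to methylsulfonyl in particular. Also open, as far as these compounds go, is whether methylsulfonyl would bring a similar gain elsewhere on this ring, or alongside the 2,6-dichloro-4-cyanophenyl group on the other nitrogen.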